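Removing a bromo group from a sulfamate-bearing steryl-sulfatase inhibitor

A few compounds are considered here, and "the series" means these few. Any claim that something is new, unique, unknown or untested is made for them only; others in the source may bear on it.

Compounds measured so far:
- compound 1, `CCN(Cc1cccc(Br)c1)c1ccc(C(=O)N2CCc3ccc(OS(N)(=O)=O)cc3C2)cc1`, 97.2%
- compound 2, `CN(C)CCCN(Cc1ccccc1)c1cccc(C(=O)N2CCc3ccc(OS(N)(=O)=O)cc3C2)c1`, 26%
- compound 3, `CCN(Cc1ccccc1)Cc1ccc(S(=O)(=O)N2CCc3ccc(OS(N)(=O)=O)cc3C2)cc1`, 31%

Three compounds built on a shared core were tested in an assay on HEK293 cells for inhibition of Steryl-sulfatase (Homo sapiens), tested at 1 uM; a lower number here means a weaker effect, a higher number a stronger effect of the compound at the concentration tested. Compound 1 gives the highest number of the three, 97.2%. The nearest of the other two is compound 3 with 31%, a gap beyond the scatter, and compound 2 with 26% lies further still. Compounds 2 and 3 differ from compound 1 in several places at once, so no single change can be read from those gaps.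

Compound 4, `CCN(Cc1ccccc1)c1ccc(C(=O)N2CCc3ccc(OS(N)(=O)=O)cc3C2)cc1`, differs from compound 1 in one place only: hydrogen in place of bromo on an aromatic carbon. The bromo sits on an aromatic carbon of a six-membered aromatic ring of carbon only, meta to a large group, and a hydrogen takes its place.

Going by the values given here, no pair of measured compounds differing in just this way has been recorded, so the size of the step cannot be taken from them. Since compound 1 already stands close to full inhibition, the step of a number 12.2 percentage points lower from compound 1 to compound 4 (beyond the scatter) is expected to be a modest drop, if any. For compound 4 in this assay an inhibition around 85% is estimated, within a range from 60% to 99%.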

Compound 4, a percentage reported as inhibition, at one concentration (the size of the read-out at that concentration, not a potency): 83.6%
Compound 4: middle estimate off by 1.4 percentage points, on the high side, and the stated range covers the measured number.
By their numbers in this assay, from the lowest: compounds 2 and 3 (each within the scatter of the next); then compound 4; then compound 1.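

Going by these compounds alone, replacing the bromo of the 3-bromobenzyl group with hydrogen is the first single change that can be read on its own, and in this assay it gives a number 13.6 percentage points lower from compound 1 to compound 4 (beyond the scatter). The bromo on this aromatic carbon therefore makes a measurable difference but is not needed for a high read-out, since compound 4 without it still gives 83.6%. Each read-out comes from one concentration and is not a potency, so the step does not show how far potency shifts, and no measurement at hand explains the change.

From the compounds shown here alone, it remains open whether chloro, methyl or methoxy on the same aromatic carbon would land nearer to compound 1 or to compound 4, and what an amine or a carboxylic acid would do there. Also open, going by these compounds, is whether the step between compound 1 and compound 4 would keep its size at a lower test concentration, further from full inhibition.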